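Dropping One Fluorine From a Legumain Nitrile Inhibitor

A few compounds are considered here, and "the series" means these few. Any claim that something is new, unique, unknown or untested is made for them only; others in the source may bear on it.

Four close relatives of one nitrile-bearing scaffold are compared in an assay on isolated protein for inhibition of legumain (Homo sapiens), with stated times of 2 min and 60 min; a lower number here means a stronger inhibitor, a higher number a weaker inhibitor. Compound 1 `C[C@@H](C(=O)N[C@H](C#N)CC(N)=O)N(Cc1ccc(-c2cccc(F)c2F)cc1)S(=O)(=O)c1ccccc1` carries a 2,3-difluorophenyl group. In this assay compound 1 gives > 10000 nM, which is a limit of the assay and not a number. Compound 3 `C[C@@H](C(=O)N[C@H](C#N)CC(N)=O)N(Cc1ccc(-c2cccc(F)c2)cc1)S(=O)(=O)c1ccccc1` differs from compound 1 only by hydrogen in place of fluoro on an aromatic carbon. In this assay compound 3 gives > 10000 nM, again a limit. The step that the two limits leave unreadable from compound 1 to compound 3 cannot be sized because both values sit at the limit of > 10000 nM in this assay, at which 2 of the 3 values shown sit. Compound 2 `CCC[C@@H](C(=O)N[C@H](C#N)CC(N)=O)N(Cc1ccc(-c2cccc(F)c2F)cc1)S(C)(=O)=O` is built on a different core, and the difference between the two cores is not broken down here. In this assay, among the compounds with values here, compound 2 gives 7750 nM, the only measured number in the set. Compound 4 `CCC[C@@H](C(=O)N[C@H](C#N)CC(N)=O)N(Cc1ccc(-c2cccc(F)c2)cc1)S(C)(=O)=O` stands to compound 2 as compound 3 stands to compound 1, by hydrogen in place of fluoro on an aromatic carbon, the same change at the same kind of place. Within the data shown here, the one measured instance of this change reads a step that the two limits leave unreadable from compound 1 to compound 3, and it cannot point either way. Resting on that, the expected step is a 1.0-fold higher number from compound 2 to compound 4 (0.01 log units; within the scatter), small. Compound 4 is therefore estimated at about 8000 nM in this assay, with a likely range from 3500 nM to 20000 nM.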

Compound 4, half-maximal inhibitory concentration: 4380 nM
For compound 4 the middle estimate is 1.8-fold (0.26 log units) above the measured one, and the stated range covers the measured number.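

In this assay, putting hydrogen in place of fluoro, which turns 2,3-difluorophenyl into 3-fluorophenyl, gives a 1.8-fold lower number from compound 2 to compound 4 (0.25 log units; within the scatter) on the core of compound 2, so on this core the change has no effect that can be told from the usual scatter. The same change on the core of compound 1 cannot be read, because neither end of that step is a number, only a limit of the assay: the limit of > 10000 nM in this assay, at which 2 of the 4 values shown sit. This leaves one readable instance of the change, so the data cannot show whether it carries from one core to the other, and agreement between the two cores can be neither claimed nor ruled out.

The compounds shown leave open how a chlorine, a methyl or a methoxy group in place of the fluoro group would read on either core. Also open, on these data alone, is whether a plain phenyl group would read any differently from 3-fluorophenyl.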